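Adding One Methyl to an Acetyl Group

A few compounds are considered here, and "the series" means these few. Any claim that something is new, unique, unknown or untested is made for them only; others in the source may bear on it.

Compound 1 `CCC(=O)O[C@@H](/C(C)=C/[C@@H](C)c1oc(CC)c(C)c(=O)c1C)[C@H](C)[C@@H](OC(=O)CC(C)C)[C@@H](C)c1oc([C@@H](C)[C@@H](O)CC)c(C)c(=O)c1C`: 12000 nM
Compound 2 `CCc1oc([C@H](C)/C=C(\C)[C@H](OC(C)=O)[C@H](C)[C@@H](OC(=O)CC(C)C)[C@@H](C)c2oc([C@@H](C)[C@H](CC)OC(C)=O)c(C)c(=O)c2C)c(C)c(=O)c1C`: 28000 nM

In a functional assay on A549 cells (Homo sapiens) for inhibition, read by MTT assay, with a stated time of 72 h (a higher number here means a weaker inhibitor, a lower number a stronger inhibitor), compound 2 is the weaker of the two measured inhibitors, at 28000 nM, a gap beyond the scatter. Compound 3 `CCC(=O)O[C@@H](/C(C)=C/[C@@H](C)c1oc(CC)c(C)c(=O)c1C)[C@H](C)[C@@H](OC(=O)CC(C)C)[C@@H](C)c1oc([C@@H](C)[C@H](CC)OC(C)=O)c(C)c(=O)c1C` differs from compound 2 by methyl in place of hydrogen on a saturated chain carbon bound to a carbonyl carbon, turning acetyl to propanoyl. Within the data shown here, no measured pair shows this change alone, so no step beyond the scatter is expected in this assay. The expected change is a 1.3-fold lower number from compound 2 to compound 3 (0.10 log units; within the scatter). Compound 3 is estimated at 22000 nM, with an expected range of 10000 nM to 45000 nM.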

Compound 3, half-maximal inhibitory concentration: 3000 nM
The estimate for compound 3 lay 7.3-fold (0.87 log units) above the measured number, and the stated range ends above it.
By their numbers in this assay, from the lowest: compound 3; then compound 1; then compound 2.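

In this assay, turning acetyl to propanoyl gives a 9.3-fold lower number from compound 2 to compound 3 (0.97 log units; beyond the scatter), so one added methyl on a saturated chain carbon bound to a carbonyl carbon is enough to move the number beyond the scatter. With the propanoyl group kept, acetyl in place of hydrogen on an oxygen on a saturated carbon gives a 4.0-fold lower number from compound 1 to compound 3 (0.60 log units; beyond the scatter), so this second change also counts. Nothing at hand explains either step.

Going by these compounds, whether a butanoyl group, a longer chain, would lower the number further stays open. So does the effect of an amine on that acyl chain.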